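The compounds below may be only part of what the source reports. "The series", "measured", "known", "first", "only" and "open" are said of these compounds alone.

Measured so far in a functional assay on MDA-MB-231 cells (Homo sapiens) for cytotoxicity, with a stated time of 3 days; on this read-out lower numbers stand for stronger inhibition and higher numbers for weaker inhibition:

Compound 1 `Clc1ccc(-c2cc(-c3cccs3)nc(-c3cccs3)c2)o1` gives 54800 nM
Compound 2 `Clc1ccc(-c2cc(-c3ccsc3)nc(-c3cccs3)c2)o1` gives 26800 nM
Compound 3 `Cc1ccsc1-c1cc(-c2ccco2)cc(-c2cccs2)n1` gives 59600 nM

Compound 2 differs from compound 1 in one place, (thiophen-3-yl in place of thiophen-2-yl on an aromatic carbon). That step gave a 2.0-fold lower number from compound 1 to compound 2 (0.31 log units; beyond the scatter). Compound 3 carries a different core from compound 1; the difference between the two cores is not broken down here. The values of compound 3 and compound 1 lie within the scatter of each other, so no order between them is claimed.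

The unmeasured compound 4 `Cc1ccsc1-c1cc(-c2ccco2)cc(-c2ccsc2)n1` stands to compound 3 as compound 2 stands to compound 1: thiophen-3-yl in place of thiophen-2-yl on an aromatic carbon. This is the same kind of change, not the same change, as the surroundings of the place differ. In compound 1 the place is meta to a 5-chlorofuran-2-yl group and meta to a thiophen-2-yl group, whereas in compound 3 it is meta to a 3-methylthiophen-2-yl group and meta to a furan-2-yl group. Among the compounds with values here, only one example of the change has been measured, which is thin support.

For compound 4 a step of about a 2.0-fold lower number from compound 3 to compound 4 (0.30 log units; within the scatter) in this assay is expected, because the corresponding step was a 2.0-fold lower number from compound 1 to compound 2 (0.31 log units; beyond the scatter). Within the data shown here, compound 4 is therefore estimated at 30000 nM, with a likely range from 15000 nM to 60000 nM; the range is kept wide in view of the single measured example.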

Compound 4, half-maximal inhibitory concentration: 41800 nM
Beside the measured number, compound 4's estimate is 1.4-fold (0.14 log units) below it; the range from low to high includes it.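

In this assay, thiophen-3-yl in place of thiophen-2-yl on the aromatic carbon next to the ring nitrogen gives a 1.4-fold lower number from compound 3 to compound 4 (0.15 log units; within the scatter) and so does not by itself separate the two compounds. Set beside the earlier example, the change does not read differently on the two cores: the same change on two cores in this assay, a 2.0-fold lower number (0.31 log units; beyond the scatter) from compound 1 to compound 2 and a 1.4-fold lower number (0.15 log units; within the scatter) from compound 3 to compound 4, 1.4-fold (0.16 log units) apart, within the scatter of two such steps
This agreement is compatible with the change carrying over between the core of compound 1 and the core of compound 3, but it does not establish a real difference between compound 3 and compound 4, and two pairs give no rule for other cores in the series or any reason for the result.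

Still open, from the compounds shown here alone, is whether the same change behaves alike when the groups in the two meta places are something other than the 5-chlorofuran-2-yl, furan-2-yl and 3-methylthiophen-2-yl groups seen here, for instance a phenyl ring or a morpholine. Within the data shown here, also open is whether an amine or a carboxylic acid in the place of the thiophene would give a step beyond the scatter, since every group at that place so far is a thiophene ring.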